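The source may hold more compounds than are shown below. What is called first, only, known or untested is meant among the compounds shown, and "the series" means these compounds.

Measured in an assay on CHO-K1 cells for displacement of a labelled ligand from melanin-concentrating hormone receptor 1 (Homo sapiens), read by scintillation proximity assay, with a stated time of 2 h; a lower number here means a stronger inhibitor, a higher number a weaker inhibitor:
compound 1 `Cc1nc(N2CCC(N3C(=O)CCC3=O)CC2)nc2ccc(NC(=O)/C=C/c3ccc(OC(F)(F)F)cc3)cc12` gives 94 nM;
compound 2 `Cc1nc(NCCCNS(C)(=O)=O)nc2ccc(NC(=O)/C=C/c3ccc(OC(F)(F)F)cc3)cc12` gives 54 nM;
compound 3 `C/C(=C\C(=O)Nc1ccc2nc(N3CCC(O)(C4CC4)CC3)nc(C)c2c1)c1ccc(Cl)cc1` gives 532 nM.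

Among these three numbers compound 1 stands second highest. Its nearest neighbour is compound 2, whose value lies within the scatter of compound 1; compound 3 sits furthest away, beyond the scatter.

Compound 4 `Cc1nc(N2CCC(NS(=O)(=O)N(C)C)CC2)nc2ccc(NC(=O)/C=C/c3ccc(OC(F)(F)F)cc3)cc12` differs from compound 1 in one place: (dimethylsulfamoyl)amino in place of 2,5-dioxopyrrolidin-1-yl on a saturated ring carbon. Among the compounds with values here, no measured pair isolates this change, so its size is uncertain. Compound 4 is expected to move by a 1.4-fold lower number from compound 1 to compound 4 (0.16 log units; within the scatter), a small step toward a lower number or none beyond the scatter, because compound 2, which also carries a sulfonamide, gives 54 nM in this assay. The estimate for compound 4 is 65 nM, with a range from 22 nM to 190 nM.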

Compound 4, half-maximal inhibitory concentration: 105 nM
Compound 4: middle estimate off by 1.6-fold (0.21 log units), on the low side; the range from low to high includes it.
By their numbers in this assay, from the lowest: compounds 2, 1 and 4 (each within the scatter of the next); then compound 3.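

In this assay, the step on this saturated ring carbon is a 1.1-fold higher number from compound 1 to compound 4 (0.05 log units; within the scatter), within the scatter, so the read-out does not separate the cyclic 2,5-dioxopyrrolidin-1-yl from the open-chain (dimethylsulfamoyl)amino. The position therefore carries both groups, with and without a hydrogen-bond donor, at values within the scatter of each other. No measurement at hand offers an explanation for this result.

Going by these compounds, whether a primary amine or a carboxylic acid on this carbon would give a step beyond the scatter remains open.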